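Chain Extension Beside the Sulfur on a Shared Core

The source may hold more compounds than are shown below. What is called first, only, known or untested is meant among the compounds shown, and "the series" means these compounds.

Compound 1 `CCSc1nnc(COc2cc(C)c3c(C)cc(=O)oc3c2)o1`, compound 2 `CCCCCSc1nnc(COc2cc(C)c3c(C)cc(=O)oc3c2)o1` and compound 3 `CCCS(=O)(=O)c1nnc(COc2cc(C)c3c(C)cc(=O)oc3c2)o1` share one core and differ only in the group on its aromatic carbon. In a functional assay on MCF7 cells (Homo sapiens) for antiproliferative activity, read by MTT assay, with a stated time of 24 h (a lower number here means a stronger inhibitor, a higher number a weaker inhibitor), compound 1 gives only a limit of > 100000 nM. Compound 2 likewise reaches only the limit of > 100000 nM in this assay. Compound 3 too gives only the limit of > 100000 nM in this assay. The change from compound 1 to compound 2 is propyl in place of hydrogen on a saturated chain carbon, two bonds along the chain from a sulfur, with a step that the two limits leave unreadable from compound 1 to compound 2. The core of compound 3 differs from that of compound 1 by propylsulfonyl in place of ethylsulfanyl on an aromatic carbon, giving a step that the two limits leave unreadable from compound 1 to compound 3 and a step that the two limits leave unreadable from compound 2 to compound 3. Compound 4 `CCCCCCS(=O)(=O)c1nnc(COc2cc(C)c3c(C)cc(=O)oc3c2)o1` differs from compound 3 by propyl in place of hydrogen on a saturated chain carbon, three bonds along the chain from a sulfonyl sulfur, the same kind of change, though here placed three bonds along the chain from a sulfonyl sulfur rather than two bonds along the chain from a sulfur. Because the limit of > 100000 nM in this assay, at which 3 of the 3 values shown sit, compound 4 is expected to give 150000 nM in this assay, an estimated step that the limit leaves unreadable from compound 3 to compound 4, most probably again only a limit.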

Compound 4, half-maximal inhibitory concentration: > 100000 nM
Compound 4 was reported as a limit; the forecaster's own chance of this, stated with the estimate: 85%; the middle value does not contradict the limit.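

Compound 4 also gives only a limit, so no step can be read among compound 1, compound 2, compound 3 and compound 4: the limit of > 100000 nM in this assay, at which 4 of the 4 values shown sit. The compounds shown leave open whether chain length or sulfanyl versus sulfonyl changes activity at all.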